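Swapping the carbinol for a cyclopropyl sulfoximine

The compounds below may be only part of what the source reports. "The series", "measured", "known", "first", "only" and "open" are said of these compounds alone.

Measured so far:
- compound 1, `CC#C[C@H]1CN(S(=O)(=O)c2ccc(N)nc2)CCN1c1ccc(C(O)(COC)C(F)(F)F)cc1`, gives 16 nM in an assay on isolated protein for inhibition of glucokinase regulatory protein (Homo sapiens), read by AlphaScreen, with stated times of 20 min and 4 h; a higher number here means a weaker inhibitor, a lower number a stronger inhibitor
- compound 2, `CC#C[C@H]1CN(S(=O)(=O)c2ccc(N)nc2)CCN1c1ccc([C@@](O)(CO)C(F)(F)F)cc1`, gives 6 nM in this assay

Among the compounds with values here, compound 2 has the lowest number of the two, and the only step seen so far, a 2.7-fold lower number from compound 1 to compound 2 (0.43 log units; beyond the scatter), was modest. Compound 3, `CC#C[C@H]1CN(S(=O)(=O)c2ccc(N)nc2)CCN1c1ccc(S(=N)(=O)C2CC2)cc1`, differs from compound 2 at the same aromatic carbon: a group of 6 heavy atoms (3 carbon, 1 nitrogen, 1 oxygen, 1 sulfur; one three-membered non-aromatic ring of carbon only) in place of a group of 8 heavy atoms (3 carbon, 2 oxygen, 3 fluorine; no ring), on an aromatic carbon. Within the data shown here, no measured step matches this change; the step from compound 1 to compound 2 only shows that trading one group for another at this position shifted the number modestly. Without a direct precedent, compound 3 is expected to stay near compound 2, with the step of a 1.7-fold higher number from compound 2 to compound 3 (0.22 log units; within the scatter) taken as the best guess and a wide range around it. Compound 3 is therefore estimated at 10 nM in this assay, within 3 nM to 40 nM.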

Compound 3, half-maximal inhibitory concentration: 256 nM
Compound 3: middle estimate off by 26-fold (1.41 log units), on the low side; the whole stated range lies below it.
By their numbers in this assay, from the lowest: compound 2; then compound 1; then compound 3.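

At this aromatic carbon, the change matters far more than the earlier step suggested: replacing either carbinol group with the cyclopropyl sulfoximine gives a 43-fold higher number from compound 2 to compound 3 (1.63 log units; beyond the scatter) and a 16-fold higher number from compound 1 to compound 3 (1.20 log units; beyond the scatter) in this assay. The position therefore accepts the two carbinol groups with only a modest shift, but it does not accept every group of similar size, and both steps point the same way. No measurement here bears on the reason for this loss.

The swap changes the whole group at once, so the compounds shown leave open whether the loss follows the sulfoximine, the cyclopropyl ring, or the departure of the carbinol with its three fluorines. A methyl sulfoximine or a plain methyl sulfone at this carbon could help to separate these possibilities.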